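The source may hold more compounds than are shown below. What is called first, only, known or untested is meant among the compounds shown, and "the series" means these compounds.

Within the data shown here, compound 3 `CNCCCCNc1c(F)cc2c(=O)c(C(=O)O)cn(Cc3ccc(-c4ccccc4)cc3)c2c1OC` is one of three compounds measured in an assay on isolated protein for inhibition of DNA topoisomerase 1 (Homo sapiens), with a stated time of 15 min, tested at 200 uM (on this read-out lower numbers stand for less inhibition and higher numbers for more inhibition at the one concentration tested (going by the name of the read-out)), and in it compound 3 gives 10%. Compound 1 `COc1c(N2CC[C@@H](C(N)=O)C2)c(F)cc2c(=O)c(C(=O)O)cn(Cc3ccc(-c4ccccc4)cc3)c12` gives 10% in this assay, and compound 2 `COc1c(N2CC[C@@H](CO)C2)c(F)cc2c(=O)c(C(=O)O)cn(Cc3ccc(-c4ccccc4)cc3)c12` gives 10%, so compound 3 stands level with both. The steps of no change at the digits printed from compound 1 to compound 2 (within the scatter), no change at the digits printed from compound 1 to compound 3 (within the scatter) and no change at the digits printed from compound 2 to compound 3 (within the scatter) all stayed within the scatter. Compound 4 `COc1c(F)c(F)cc2c(=O)c(C(=O)O)cn(Cc3ccc(-c4ccccc4)cc3)c12` differs from compound 3 by fluoro in place of (4-(methylamino)butyl)amino on an aromatic carbon. Among the measured compounds shown here, no measured step puts fluoro in place of this amine, so the expectation rests only on the flat picture across compounds 1, 2 and 3. The step of no change at the digits printed from compound 3 to compound 4 (within the scatter) is therefore expected to be none beyond the scatter. Compound 4 is estimated to give 10% in this assay, within a range from 0% to 25%.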

Compound 4, a percentage reported as inhibition, at one concentration (the size of the read-out at that concentration, not a potency): "not active" (no number reported)
The entry for compound 4 holds no number; the estimate stays without a comparison.
By their numbers in this assay, from the lowest: compounds 1, 2 and 3 (each within the scatter of the next).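

In this assay, among these compounds, compound 4 is reported as "not active" without a number, so no step from compound 3 to compound 4 can be read. The compounds shown leave open how much inhibition changes when fluoro replaces the amine. Nothing shown offers an explanation for this result.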